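The source may hold more compounds than are shown below. What is called first, only, known or untested is meant among the compounds shown, and "the series" means these compounds.

Measured so far in an assay on isolated protein (strain albino) for antagonist activity at Voltage-dependent L-type calcium channel subunit alpha-1C (Cavia porcellus); a lower number here means a stronger inhibitor, a higher number a weaker inhibitor: compound 1 `CSc1ncc(C2C(C(=O)OC(C)C)=C(C)NC(C)=C2C(=O)OC(C)C)n1Nc1ccccc1` gives 2.16 nM; compound 2 `COCCOC(=O)C1=C(C)NC(C)=C(C(=O)OC(C)C)C1c1cnc(SC)n1Nc1ccccc1` gives 53.4 nM.

Compound 2 stands at the higher of the two numbers, the step being a 25-fold higher number from compound 1 to compound 2 (1.39 log units; beyond the scatter). Compound 3 `CSc1ncc(C2C(C(=O)OCCCc3ccccc3)=C(C)NC(C)=C2C(=O)OC(C)C)n1Nc1ccccc1` differs from compound 2 by benzyl in place of methoxy on a saturated chain carbon, two bonds along the chain from an oxygen next to a carbonyl group. For the measured compounds named here, only the step from compound 1 to compound 2 touches this ester position, and it was large; it shows the position is sensitive but gives no direction for the present change. A step of moderate size, estimated as a 3.6-fold lower number from compound 2 to compound 3 (0.55 log units; beyond the scatter), is expected. Compound 3 is estimated at 15 nM in this assay, between 3 nM and 80 nM.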

Compound 3, half-maximal inhibitory concentration: 6.22 nM
The estimate for compound 3 lay 2.4-fold (0.38 log units) above the measured number; the range from low to high includes it.
By their numbers in this assay, from the lowest: compound 1; then compound 3; then compound 2.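

In this assay, 3-phenylpropyl in place of 2-methoxyethyl gives an 8.6-fold lower number from compound 2 to compound 3 (0.93 log units; beyond the scatter), so at this ester position the larger group does not carry the penalty seen with 2-methoxyethyl. Against isopropyl, 3-phenylpropyl still gives a 2.9-fold higher number from compound 1 to compound 3 (0.46 log units; beyond the scatter), leaving the isopropyl ester of compound 1 with the lowest number of the three. No measurement shown here accounts for these differences.

As far as these compounds go, it remains open whether the aromatic ring or the removal of the methoxy oxygen accounts for the recovery. A plain pentyl chain or a chain ending in an amine could help separate these readings.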